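Methyl for bromo on a shared amide-bearing ring

The source may hold more compounds than are shown below. What is called first, only, known or untested is meant among the compounds shown, and "the series" means these compounds.

Measured compounds and their values:
compound 1 `Cc1ccc(NC(=O)C2(C(=O)Nc3ccc(Nc4ncc(F)c(-c5cc(F)c6nc(C)n(C(C)C)c6c5)n4)cc3)CC2)cc1`: 16 nM
compound 2 `Cc1nc2c(F)cc(-c3nc(Nc4ccc(NC(=O)C5(C(=O)Nc6ccc(Br)cc6)CC5)cc4)ncc3F)cc2n1C(C)C`: 120 nM
compound 3 `Cc1nc2c(F)cc(-c3nc(Nc4ccc(CNC(=O)C5(C(=O)Nc6ccc(Br)cc6)CC5)cc4)ncc3F)cc2n1C(C)C`: 109 nM

In a functional assay on T47D cells (Homo sapiens) for antiproliferative activity, read by CCK-8 assay, with a stated time of 72 h (on this read-out lower numbers stand for stronger inhibition and higher numbers for weaker inhibition), compound 1 gives 16 nM, compound 2 gives 120 nM and compound 3 gives 109 nM. Compound 1 differs from compound 2 by methyl in place of bromo on an aromatic carbon, and that single change made a step of a 7.5-fold lower number from compound 2 to compound 1 (0.88 log units; beyond the scatter). The difference between the core of compound 2 and the core of compound 3 is not broken down here; their two values lie close together. Compound 4 `Cc1ccc(NC(=O)C2(C(=O)NCc3ccc(Nc4ncc(F)c(-c5cc(F)c6nc(C)n(C(C)C)c6c5)n4)cc3)CC2)cc1` is not yet measured. It differs from compound 3 by methyl in place of bromo on an aromatic carbon, the same change already seen from compound 2 to compound 1. Because the earlier step was a 7.5-fold lower number from compound 2 to compound 1 (0.88 log units; beyond the scatter), a step of similar size is expected for compound 4, namely a 6.1-fold lower number from compound 3 to compound 4 (0.78 log units; beyond the scatter) in this assay. Compound 4 is therefore estimated at 18 nM, between 7 nM and 50 nM.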

Compound 4, half-maximal inhibitory concentration: 771 nM
Compound 4: the middle estimate sits 43-fold (1.63 log units) below what was measured, and the stated range ends below it.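

In this assay, methyl in place of bromo gave a 7.1-fold higher number from compound 3 to compound 4 (0.85 log units; beyond the scatter), so the change did not carry over from the core of compound 2 to the core of compound 3. This pair of cores shows only that neither the size nor the direction of the step can be assumed to transfer in this series; it does not show which feature of the cores is responsible, or how the change would behave on any further core. The two steps run in opposite directions and differ by more than scatter: the same change on two cores in this assay, a 7.5-fold lower number (0.88 log units; beyond the scatter) from compound 2 to compound 1 and a 7.1-fold higher number (0.85 log units; beyond the scatter) from compound 3 to compound 4, 53-fold (1.72 log units) apart, beyond the scatter of two such steps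

From the compounds shown here alone, whether a chloro or methoxy group in the same place would show the same split between the two cores remains open. So does the effect of a longer chain in the core of compound 4.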